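Cyano in Place of Trifluoromethyl on a Weak Antiproliferative Series

This account rests on a few compounds, and the source may have more. Where it says the series, first, only, none or still open, it means among the compounds named here.

Measured compounds:
compound 1, `CCc1cc(=O)c2ccc(OCc3cccc(C)c3)c(C)c2o1`: 28600 nM
compound 2, `CCc1cc(=O)c2ccc(OCc3cccc(C(F)(F)F)c3)c(C)c2o1`: > 27600 nM

In a functional assay on KB cells (Homo sapiens) for antiproliferative activity, read by sulforhodamine B assay, with a stated time of 72 h (a higher number here means a weaker inhibitor of growth, a lower number a stronger inhibitor of growth), compound 1 gives 28600 nM. For compound 2 the assay reports only a limit, > 27600 nM. The step that the limit leaves unreadable from compound 1 to compound 2 therefore cannot be sized; what is known is the limit of > 27600 nM in this assay, at which 1 of the 2 values shown sits. Compound 2 thus stands at that limit, without a number of its own.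

Compound 3, `CCc1cc(=O)c2ccc(OCc3cccc(C#N)c3)c(C)c2o1`, differs from compound 2 by cyano in place of trifluoromethyl on an aromatic carbon. Among the compounds with values here, the only measured step touching this part of the molecule is the one from compound 1 to compound 2, and its size is not readable. Within the data shown here, no measured step therefore sets a direction for the change in this assay, and the series as a whole sits at weak inhibition.

Compound 3 is expected to remain a weak inhibitor, at about 30000 nM, within 10000 nM to 100000 nM. The step that the limit leaves unreadable from compound 2 to compound 3 is expected to be none beyond the scatter.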

Compound 3, concentration for 50% growth inhibition: > 31300 nM
Compound 3 was reported as a limit; the forecaster's own chance of this, stated with the estimate: 60%; middle value at least 1.0-fold (0.01 log units) away from the limit.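

Compound 3 gives > 31300 nM as a limit in this assay and has no number of its own. Cyano in place of methyl on this aromatic carbon gives an at least 1.0-fold higher number from compound 1 to compound 3 (0.03 log units; that floor lies within the scatter) and so brings no sign of stronger inhibition of growth. The steps that join compound 2 to compound 1 and to compound 3 cannot be read, so trifluoromethyl and cyano cannot be ranked against each other here.

Methyl, trifluoromethyl and cyano all leave the series at weak inhibition, and it stays open whether an amine or a carboxylic acid on this aromatic carbon would bring a stronger inhibitor of growth. As far as these compounds go, it is also open how far compound 2 and compound 3 lie beyond their limits.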